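Swapping the carbamate ester group for an oxetane

The source may report more compounds than this note shows. Statements on the series, on what has been measured and on what is new or still open speak of the compounds shown alone.

Compound 2 `CCC1(OC(=O)N2CCC(Oc3ncnc(Oc4ccc(S(C)(=O)=O)nc4C)c3F)CC2)CC1` is the weaker of the two measured compounds in a functional assay on isolated protein for inhibition of Glucose-dependent insulinotropic receptor (Rattus norvegicus), read by HTRF and cAMP accumulation (a lower number here means that less compound is needed, a higher number that more compound is needed for the effect), where compound 2 gives 333 nM. Among the measured compounds shown here, its only neighbour is compound 1 `Cc1nc(S(C)(=O)=O)ccc1Oc1ncnc(OC2CCN(C(=O)OC(C)(C)C(F)(F)F)CC2)c1F`, which in this assay gives 47.2 nM; the step of a 7.1-fold higher number from compound 1 to compound 2 (0.85 log units; beyond the scatter) lies beyond the scatter. Compound 3 `Cc1nc(S(C)(=O)=O)ccc1Oc1ncnc(OC2CCN(C(=O)OC3COC3)CC2)c1F` has not yet been measured. It differs from compound 2 in one place: oxetan-3-yl in place of 1-ethylcyclopropyl on an oxygen next to a carbonyl group. For the measured compounds named here, the single measured step bears only loosely on this change, since it also alters the group on the oxygen next to the carbonyl group and shows that this position can move the number by a 7.1-fold higher number from compound 1 to compound 2 (0.85 log units; beyond the scatter), without saying what a small ring bearing one acceptor will do. The direction is therefore open. Compound 3 is expected to land near compound 2, with a step of a 1.2-fold higher number from compound 2 to compound 3 (0.08 log units; within the scatter) that could fall either way. The estimate for compound 3 in this assay is 400 nM, within a range from 100 nM to 1600 nM.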

Compound 3, half-maximal effective concentration: 2500 nM
Compound 3: middle estimate off by 6.3-fold (0.80 log units), on the low side; measured number above the stated range.
By their numbers in this assay, from the lowest: compound 1; then compound 2; then compound 3.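

In this assay the change at this position is not neutral: oxetan-3-yl in place of 1-ethylcyclopropyl gives a 7.5-fold higher number from compound 2 to compound 3 (0.88 log units; beyond the scatter) and makes compound 3 the weakest of the three. Among the compounds shown here, the earlier step showed only that the group on the oxygen next to a carbonyl group can move the number, whereas this one shows that a four-membered ring with one hetero atom and one hydrogen-bond acceptor can be poorly tolerated there, even though it differs from 1-ethylcyclopropyl by a single heavy atom. Measured against the best group shown, the same position spans a 53-fold higher number from compound 1 to compound 3 (1.72 log units; beyond the scatter) on this one change, and nothing at hand accounts for the loss.

The ring size and the ring oxygen change together in this step, so the compounds shown cannot tell which of them goes with the higher number. A cyclobutyl group would keep the four-membered ring with carbon only, and a tetrahydrofuran-3-yl group would keep the ring oxygen in a larger ring, so either would pull the two apart.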